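A few compounds are considered here, and "the series" means these few. Any claim that something is new, unique, unknown or untested is made for them only; others in the source may bear on it.

Working notes on the shared core. Compound 1 `CCOC(=O)C12C(=O)OCC=C1COC2c1ccccc1F` reaches only the limit of a functional assay on A549 cells (Homo sapiens) for cytotoxicity, read by MTT assay (on this read-out higher numbers stand for weaker inhibition and lower numbers for stronger inhibition), giving > 1000000 nM. Compound 3 `CCOC(=O)C12C(=O)OCC=C1COC2c1ccc(Cl)c(Cl)c1` likewise sits at a limit, giving > 1000000 nM. Among the compounds with values here, compound 2 `CCOC(=O)C12C(=O)OCC=C1COC2c1cccc(Cl)c1` gives 28400 nM, the only number among the three values shown. Two of the three values rest at the limit of > 1000000 nM in this assay, at which 2 of the 3 values shown sit. Both measured steps are large: an at least 35-fold lower number from compound 1 to compound 2 (1.54 log units; beyond the scatter) and an at least 35-fold higher number from compound 2 to compound 3 (1.54 log units; beyond the scatter). Compound 4 `CCOC(=O)C12C(=O)OCC=C1COC2c1ccco1` differs from compound 2 by furan-2-yl in place of 3-chlorophenyl on a saturated ring carbon. Both measured steps bear on this change, each altering the aryl group on that saturated ring carbon, and each was large, so a large step is expected here too, toward a higher number, as with an at least 35-fold higher number from compound 2 to compound 3 (1.54 log units; beyond the scatter). Compound 4 is therefore estimated at 150000 nM, within 20000 nM to 1000000 nM, and may reach only a limit. The expected step is a 5.3-fold higher number from compound 2 to compound 4 (0.72 log units; beyond the scatter).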

Compound 4, half-maximal inhibitory concentration: > 1000000 nM
Compound 4: no number, only a limit (the forecaster's own chance of this, stated with the estimate: 50%); middle value at least 6.6-fold (0.82 log units) from the limit.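

Furan-2-yl in place of 3-chlorophenyl on this saturated ring carbon gives an at least 35-fold higher number from compound 2 to compound 4 (1.54 log units; beyond the scatter), so a five-membered aromatic ring with 1 hetero atom joins the groups that end at the limit. Among the four groups shown at this carbon, only 3-chlorophenyl gives a number in this assay: the limit of > 1000000 nM in this assay, at which 3 of the 4 values shown sit. The step from compound 1 to compound 4 cannot be read, as both values are limits.

Open, from the compounds shown here alone, is whether 3-bromophenyl or 3-aminophenyl at this carbon would give a number. Also open, going by these compounds, is how a carboxylic acid in place of the ethoxycarbonyl group would read.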